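A few compounds are considered here, and "the series" means these few. Any claim that something is new, unique, unknown or untested is made for them only; others in the source may bear on it.

Measured so far:
- compound 1 `O=C(O)c1ccc(C(=O)/C(=C\c2ccc(Br)c([N+](=O)[O-])c2)SCc2ccc(Br)cc2)cc1`: < 1000 ug/mL
- compound 2 `O=C(O)c1ccc(C(=O)/C(=C\c2ccc(Br)c([N+](=O)[O-])c2)SCc2ccc(F)cc2)cc1`: < 1000 ug/mL

Compound 1 and compound 2 share one core and differ only in a single halogen on the outer ring. In a physicochemical assay for solubility (on this read-out higher numbers stand for higher solubility and lower numbers for lower solubility), compound 1 gives < 1000 ug/mL, which is a limit of the assay and not a number. Compound 2 likewise gives < 1000 ug/mL, again a limit rather than a measured figure. Compound 1 therefore stands at a limit on this read-out, with no exact number known. Going by the values given here, the one measured step, a step that the two limits leave unreadable from compound 1 to compound 2, is hidden by the limit of < 1000 ug/mL in this assay, at which 2 of the 2 values shown sit, so its size cannot be read.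

Compound 3 `O=C(O)c1ccc(C(=O)/C(=C\c2ccc(O)c([N+](=O)[O-])c2)SCc2ccc(Br)cc2)cc1` differs from compound 1 in one place: hydroxy in place of bromo on an aromatic carbon. Among the compounds with values here, no measured step bears on this change: the only step recorded is the one from compound 1 to compound 2, and it is unreadable. Nothing measured here points to a direction or size of change.

For compound 3 the estimate is 200 ug/mL, with a range from 30 ug/mL to 1000 ug/mL. This estimate corresponds to an expected step that the limit leaves unreadable from compound 1 to compound 3, and the assay may well again report only a limit.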

Compound 3, solubility: < 1000 ug/mL
Compound 3 ended at the assay's limit (the forecaster's own chance of this, stated with the estimate: 35%); the middle value lies beyond the limit too.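

The step from compound 1 to compound 3 cannot be read, because both values are limits of the assay and not numbers: the limit of < 1000 ug/mL in this assay, at which 3 of the 3 values shown sit.

The compounds shown leave open how compound 1, compound 2 and compound 3 truly compare in this assay, and so whether hydroxy or fluoro in place of bromo changes the read-out at all, or in which direction.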